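A few compounds are considered here, and "the series" means these few. Any claim that something is new, unique, unknown or untested is made for them only; others in the source may bear on it.

Of the compounds shown here, two have numbers so far in a functional assay on FL5.12 cells (Mus musculus) for cytotoxicity, read by flow cytometry, with a stated time of 48 h; on this read-out lower numbers stand for stronger inhibition and higher numbers for weaker inhibition. Compound 1 (`CCCCCCCCCC/C=C/c1ccc(CO[C@@H]2CN[C@@H](CO)C2)cc1`) gives 2800 nM, and compound 2 (`CCCC/C=C/c1ccc(CO[C@H]2CN[C@H](CO)C2)cc1`) gives 5700 nM. Compound 2 therefore holds the higher number of the pair, which makes it the weaker inhibitor, and its gap to compound 1 lies beyond the usual scatter of repeated measurements.

Compound 3 (`CCCCCCCCCC/C=C/c1ccc(CO[C@H]2CN[C@H](CO)C2)cc1`) differs from compound 2 by a single change: hexyl in place of hydrogen on a saturated chain carbon, four bonds along the chain from a double-bonded chain carbon. Going by the values given here, no measured pair shows this change on its own, so the size of its effect remains uncertain. The closest guide among the measured compounds is compound 1 at 2800 nM. In this assay a modest move toward a lower number, just beyond the scatter, is expected, and the estimated step is a 2.1-fold lower number from compound 2 to compound 3 (0.32 log units; beyond the scatter). For compound 3 the estimated value is 2700 nM, with an expected range of 1300 nM to 5500 nM.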

Compound 3, half-maximal inhibitory concentration: 2400 nM
Beside the measured number, compound 3's estimate is 1.1-fold (0.05 log units) above it; the measured number falls inside the stated range.
By their numbers in this assay, from the lowest: compounds 3 and 1 (each within the scatter of the next); then compound 2.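

In this assay, going by these compounds alone, hexyl in place of hydrogen on a saturated chain carbon, four bonds along the chain from a double-bonded chain carbon, gives a 2.4-fold lower number from compound 2 to compound 3 (0.38 log units; beyond the scatter), so this pair offers the first view of the change on its own and links the longer chain to a modest gain. Reversing the two ring stereocentres as drawn gives a 1.2-fold lower number from compound 1 to compound 3 (0.07 log units; within the scatter), so with this longer chain the difference in configuration does not stand out from the usual variation between repeat measurements. This reading of configuration is a direct one, though it rests on a single pair: the fact that compounds 1 and 3 differ only in the configuration as drawn.

On these data alone, it remains open whether a still longer chain, or a carboxylic acid or an amine in place of hexyl at this position, would move the number further. As far as these compounds go, it is also open whether configuration would count for as little with the shorter chain of compound 2.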